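Moving the bromine in the bromophenyl series

A few compounds are considered here, and "the series" means these few. Any claim that something is new, unique, unknown or untested is made for them only; others in the source may bear on it.

In a functional assay (a lower number here means a stronger inhibitor, a higher number a weaker inhibitor), compound 2 `CC(C)=CCOc1ccc2c(c1)OC(c1ccccc1Br)CC2=O` gives 3180 nM, and compound 1 `CC(C)=CCOc1ccc2c(c1)OC(c1cccc(Cl)c1)CC2=O` gives 6300 nM. Among the compounds with values here, these two values lie within the scatter of each other, so compound 2 stands level with the only other measurement. The next compound to be tested is compound 3 `CC(C)=CCOc1ccc2c(c1)OC(c1cccc(Br)c1)CC2=O`, which has the same atoms as compound 2, joined differently: 3-bromophenyl in place of 2-bromophenyl on a saturated ring carbon. The change is 3-bromophenyl in place of 2-bromophenyl on a saturated ring carbon, next to the ring oxygen, with the shared core untouched. Within the data shown here, the only measured step bearing on this change is a 2.0-fold lower number from compound 1 to compound 2 (0.30 log units; within the scatter), so no step beyond the scatter is expected in this assay. The estimated change is a 1.5-fold higher number from compound 2 to compound 3 (0.18 log units; within the scatter). The expected value for compound 3 is 4800 nM, with an estimated range of 2000 nM to 11000 nM.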

Compound 3, half-maximal inhibitory concentration: 5280 nM
Beside the measured number, compound 3's estimate is 1.1-fold (0.04 log units) below it; measured number inside the range.
By their numbers in this assay, from the lowest: compounds 2, 3 and 1 (each within the scatter of the next).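

Placing the halogen differently on the phenyl ring does not separate these compounds: 3-bromophenyl in place of 2-bromophenyl gives a 1.7-fold higher number from compound 2 to compound 3 (0.22 log units; within the scatter) in this assay, so this change, on a saturated ring carbon next to the ring oxygen, has no readable effect on the number. The new compound also gives the series its first comparison of two halogens with the substituent otherwise unchanged, and bromo in place of chloro gives a 1.2-fold lower number from compound 1 to compound 3 (0.08 log units; within the scatter), again with no readable difference. No accompanying measurement offers an explanation for either step.

With only chloro and bromo phenyl groups at this carbon, these steps describe a narrow range of substituents and give no ranking among the three compounds. Going by these compounds, whether an amine or a carboxylic acid on the phenyl ring would move the number beyond the scatter remains open.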